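Swapping an Ester Chain for a Fluorobenzyl Arm

The source may hold more compounds than are shown below. What is called first, only, known or untested is meant among the compounds shown, and "the series" means these compounds.

In a functional assay on A549 cells (Homo sapiens) for inhibition, read by sulforhodamine B assay, with a stated time of 48 h (on this read-out higher numbers stand for weaker inhibition and lower numbers for stronger inhibition), three compounds have been measured so far. Compound 1 `CCOC(=O)CCO/N=C(/c1ccc(OC)c(OC)c1OC)c1cccc2ccccc12` gives 19600 nM, and compound 3 `COc1ccc(C(c2ccccc2O)c2cccc3ccccc23)c(OC)c1OC` gives 13600 nM. Compound 2 `CCOC(=O)C(C)C(O)(c1ccc(OC)c(OC)c1OC)c1cccc2ccccc12` gives 4000 nM, the lowest of the three numbers; the nearest value belongs to compound 3 and the furthest to compound 1, and both gaps lie beyond the usual scatter. Compound 4 `COc1ccc(C(O)(Cc2ccc(F)cc2)c2cccc3ccccc23)c(OC)c1OC` has not yet been measured and differs from compound 2 in one place: 4-fluorobenzyl in place of 1-(ethoxycarbonyl)ethyl on a saturated chain carbon bound to two aromatic carbons and an oxygen on a saturated carbon. Within the data shown here, no pair of measured compounds shows this kind of change, so there is no direct guide to its size or direction. Compound 4 is therefore expected to sit near compound 2, with an estimate of 5000 nM and a range from 1500 nM to 16000 nM. The expected step is a 1.3-fold higher number from compound 2 to compound 4 (0.10 log units; within the scatter), which is within the scatter.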

Compound 4, half-maximal inhibitory concentration: 5940 nM
Estimate against measurement, compound 4: 1.2-fold (0.07 log units) below; the measured number falls inside the stated range.
By their numbers in this assay, from the lowest: compounds 2 and 4 (each within the scatter of the next); then compounds 3 and 1 (each within the scatter of the next).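

Replacing 1-(ethoxycarbonyl)ethyl with 4-fluorobenzyl on this carbon gives a 1.5-fold higher number from compound 2 to compound 4 (0.17 log units; within the scatter) in this assay and so leaves inhibition of these cells unchanged within normal assay variation. This position therefore accepts an arm with an aromatic ring and no hydrogen-bond acceptors as well as an open ester chain that carries such acceptors. For this pair, the ester is not needed to keep this level of inhibition. As far as these compounds go, whether a plain benzyl, an amine or a carboxylic acid on this carbon would read alike stays open. No measurement shown explains why these two arms read alike.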